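Bromo to Iodo on the Shared Core: A Halogen Swap

A few compounds are considered here, and "the series" means these few. Any claim that something is new, unique, unknown or untested is made for them only; others in the source may bear on it.

Measured so far:
- compound 1 `C=CCNC(=O)n1c(-c2ccc(OC)cc2)cc(=O)c2c(OC)cc(OC)cc21`: 74000 nM
- compound 2 `COc1ccc(-c2c(Br)c(=O)c3c(OC)cc(OC)cc3n2S(=O)(=O)c2ccc(OC)cc2)cc1`: 49700 nM

Of the compounds shown here, two have been tested in an ADME assay on BJ cells (Homo sapiens) for antiproliferative activity, with a stated time of 72 h; on this read-out lower numbers stand for an effect already at smaller amounts and higher numbers for an effect only at larger amounts of compound. Compound 1 gives 74000 nM and compound 2 gives 49700 nM. Compound 2 carries the lower of the two numbers, but the two values lie within the usual scatter of each other, so nothing separates them with confidence in this assay.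

Compound 3 `COc1ccc(-c2c(I)c(=O)c3c(OC)cc(OC)cc3n2S(=O)(=O)c2ccc(OC)cc2)cc1` is the next step from compound 2. The change is iodo in place of bromo on an aromatic carbon — iodo in place of bromo on an aromatic carbon, with everything else on the shared core untouched.

Going by the values given here, no step between two measured compounds of this kind is available, so the expectation must rest on compound 2 alone and on the small size of the change. Exchanging one halogen for its heavier neighbour at the same position rarely moves a cellular antiproliferative read-out far, and here nothing in the data argues for a shift in either direction. The step from compound 2 to compound 3 in this assay is therefore expected to be a 1.1-fold lower number from compound 2 to compound 3 (0.04 log units; within the scatter), within the scatter. Compound 3 is estimated at 45000 nM, with a range from 20000 nM to 110000 nM.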

Compound 3, half-maximal effective concentration: > 34400 nM
Compound 3: a limit, no number; the forecaster's own chance of this, stated with the estimate: 20%; the middle value is on the limit's open side.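

In this assay, going by these compounds alone, compound 3 gives > 34400 nM, which is a limit of the assay and not a number, so no step from compound 2 to compound 3 can be read. The compounds shown leave open whether iodo in place of bromo on an aromatic carbon changes the result in this assay at all, and in which direction.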